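The compounds below may be only part of what the source reports. "The series", "measured", "known", "first", "only" and "open" are said of these compounds alone.

Measured compounds:
compound 1 `ClCc1ccc(Cn2cnc3c(Cl)ncnc32)cc1` — 72400 nM
compound 2 `ClCc1cccc(Cn2cnc3c(Cl)ncnc32)c1` — 18200 nM

In a functional assay on PC-3 cells (Homo sapiens) for cytotoxicity, read by sulforhodamine B assay, with a stated time of 48 h (on this read-out higher numbers stand for weaker inhibition of growth and lower numbers for stronger inhibition of growth), compound 2 gives the lowest of the two numbers; compound 1 gives the higher number, a gap well beyond the scatter. Compound 3 `ClCc1cccc(Cn2cnc3c(Cl)nc(Cl)nc32)c1` differs from compound 2 by chloro in place of hydrogen on an aromatic carbon. Within the data shown here, no measured pair shows this change, so its direction is unknown from the data. Compound 3 is expected to sit near compound 2 or somewhat lower, a step of a 1.5-fold lower number from compound 2 to compound 3 (0.18 log units; within the scatter) of modest size. The estimate for compound 3 is 12000 nM, with a range from 4000 nM to 40000 nM.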

Compound 3, concentration for total growth inhibition: 5010 nM
Estimate against measurement, compound 3: 2.4-fold (0.38 log units) above, and the stated range covers the measured number.
By their numbers in this assay, from the lowest: compound 3; then compound 2; then compound 1.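

In this assay, putting chloro in place of hydrogen on the aromatic carbon between two ring nitrogen atoms gives a 3.6-fold lower number from compound 2 to compound 3 (0.56 log units; beyond the scatter). Among these compounds, compound 1 and compound 2 both carry hydrogen there, so only this step shows that this carbon of the shared core tolerates a substituent and that chloro here goes with stronger inhibition of growth. Nothing available accounts for the size or direction of this step. The compounds shown leave open whether an amine or a methoxy group on this carbon would act as chloro does. They also leave open whether the same step would appear on the core of compound 1.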